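Adding Fluorine to the Pyridine Ring of Compound 3

A few compounds are considered here, and "the series" means these few. Any claim that something is new, unique, unknown or untested is made for them only; others in the source may bear on it.

In a functional assay on M14 cells (Homo sapiens) for antiproliferative activity, with a stated time of 72 h (on this read-out higher numbers stand for weaker inhibition and lower numbers for stronger inhibition), compound 1 `C=CC[C@H]1C[C@]2([C@@H](C)Cc3ccc(OC)cc3)OCOC2=CC1=O` gives 20 nM. Compound 2 `C=CC[C@H]1C[C@]2([C@@H](C)Cc3ccc(O)cc3)OCOC2=CC1=O` gives > 20000 nM, which is a limit of the measurement and not a number. Compound 3 `C=CC[C@H]1C[C@]2([C@@H](C)Cc3ccc(OC)nc3)OCOC2=CC1=O` gives 180 nM, the highest of the two numbers available, reached by a 9.0-fold higher number from compound 1 to compound 3 (0.95 log units; beyond the scatter). Compound 4 `C=CC[C@H]1C[C@]2([C@@H](C)Cc3cnc(OC)cc3F)OCOC2=CC1=O` differs from compound 3 by fluoro in place of hydrogen on an aromatic carbon. Neither measured step touches this position: an at least 1000-fold higher number from compound 1 to compound 2 (3.00 log units; beyond the scatter) concerns the methyl on the oxygen, while the other step exchanges the whole aromatic ring. Going by the values given here, with no closer precedent, the expected step is no change at the digits printed from compound 3 to compound 4 (within the scatter), which stays within the scatter. Compound 4 is therefore estimated at 180 nM, most likely between 60 nM and 600 nM.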

Compound 4, half-maximal inhibitory concentration: 8000 nM
Beside the measured number, compound 4's estimate is 44-fold (1.65 log units) below it; the measured number lies above the stated range.
By their numbers in this assay, from the lowest: compound 1; then compound 3; then compound 4. At a limit, above all of these: compound 2.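

A single fluoro in place of hydrogen, opposite the ring nitrogen and ortho to a large group, is far from a neutral change: in this assay it gives a 44-fold higher number from compound 3 to compound 4 (1.65 log units; beyond the scatter). Going by these compounds alone, this carbon of the aromatic ring is therefore sensitive to one added heavy atom, something the earlier steps, at the oxygen or on the whole ring, could not show. Compound 4 still gives a number and does not reach the limit of the measurement: the limit of > 20000 nM in this assay, at which 1 of the 4 values shown sits.

Going by these compounds, whether any group at this carbon does the same, or fluoro alone, stays open. A methyl, a chloro or a hydroxyl here would help to tell.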